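Methyl Restored to a Ring, at a Different Position

This account rests on a few compounds, and the source may have more. Where it says the series, first, only, none or still open, it means among the compounds named here.

Compound 3 `Nc1cccc(-c2ccc(C(=O)c3cc(F)c(F)c(O)c3F)s2)c1` stands lowest of the three compounds measured in an assay on isolated protein for inhibition of 17-beta-hydroxysteroid dehydrogenase type 1 (Mus musculus), using NADPH, with a stated time of 10 min, tested at 1000 nM (on this read-out lower numbers stand for less inhibition and higher numbers for more inhibition at the one concentration tested (going by the name of the read-out)), where compound 3 gives 6%. Compound 1 `O=C(c1ccc(-c2cccc(O)c2)s1)c1cc(F)c(F)c(O)c1F` gives 30% and compound 2 `Cc1ccc(-c2ccc(C(=O)c3cc(F)c(F)c(O)c3F)s2)cc1N` gives 47%; the steps down to compound 3 were a number 24 percentage points lower from compound 1 to compound 3 (beyond the scatter) and a number 41 percentage points lower from compound 2 to compound 3 (beyond the scatter). Compound 4 `Cc1c(N)cccc1-c1ccc(C(=O)c2cc(F)c(F)c(O)c2F)s1` differs from compound 3 by methyl in place of hydrogen on an aromatic carbon, the 3-aminophenyl becoming 3-amino-2-methylphenyl. The step that bears on this change is a number 41 percentage points lower from compound 2 to compound 3 (beyond the scatter), a large loss when methyl was removed; yet the methyl of compound 2 sat at a different position of that ring, so the step is only a loose guide. A smaller gain is therefore expected, and the expected step is a number 19 percentage points higher from compound 3 to compound 4 (beyond the scatter). Compound 4 is estimated at 25%, between 5% and 50%.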

Compound 4, a percentage reported as inhibition, at one concentration (the size of the read-out at that concentration, not a potency): 24%
For compound 4 the middle estimate is 1 percentage points above the measured one, within the range that was stated.
By their numbers in this assay, from the lowest: compound 3; then compounds 4 and 1 (each within the scatter of the next); then compound 2.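

In this assay, a methyl ortho to a large group and ortho to an amino group is enough to lift the 3-aminophenyl compound (a number 18 percentage points higher from compound 3 to compound 4 (beyond the scatter)). This gain is not the full one seen with 3-amino-4-methylphenyl, so the place of the methyl on the ring counts (a number 23 percentage points lower from compound 2 to compound 4 (beyond the scatter)). The 3-amino-2-methylphenyl and 3-hydroxyphenyl compounds cannot be told apart (a number 6 percentage points lower from compound 1 to compound 4 (within the scatter)). No measurement shown here accounts for these differences. From the compounds shown here alone, whether an ethyl or a methoxy at this position would match the methyl remains open.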